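Ring replacement by ethoxy: solubility notes on the series

The source may report more compounds than this note shows. Statements on the series, on what has been measured and on what is new or still open speak of the compounds shown alone.

Measured so far:
Compound 1, `Cc1cc(C(=O)NNS(=O)(=O)c2ccccc2F)cc(-c2ccccn2)c1`: in a physicochemical assay for solubility, read by nephelometry, measured as kinetic solubility, at pH 2 (on this read-out higher numbers stand for higher solubility and lower numbers for lower solubility), compound 1 gives > 100 ug/mL, a limit of the assay and not a number.
Compound 2, `Cc1cc(-n2nccn2)cc(C(=O)NNS(=O)(=O)c2ccccc2)c1F`: compound 2 gives 25 ug/mL.
Compound 3, `Cc1cc(C(=O)NNS(=O)(=O)c2ccccc2F)cc(-c2ccco2)c1`: compound 3 gives 6.3 ug/mL.

Of the two numbers in hand, compound 3 holds the lower one and compound 2 the higher. Compound 1 stands at the limit of this assay (the limit of > 100 ug/mL in this assay, at which 1 of the 3 values shown sits). Among the measured compounds shown here, the only step measured across a single change is an at least 15-fold lower number from compound 1 to compound 3 (1.20 log units; beyond the scatter). Its true size is known only as a minimum.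

Compound 4, `CCOc1cc(C)cc(C(=O)NNS(=O)(=O)c2ccccc2F)c1`, differs from compound 3 by ethoxy in place of furan-2-yl on an aromatic carbon. For the measured compounds named here, no measured step swaps an aromatic ring for a chain, so the step from compound 1 to compound 3 is the only guide: it places the furan-2-yl group on the shared core beside the lowest number seen, and taking it out in favour of ethoxy is expected to move the number back up, though not as far as the limit. The step expected is a 2.4-fold higher number from compound 3 to compound 4 (0.38 log units; beyond the scatter). Compound 4 is therefore estimated at 15 ug/mL, with a likely range from 5 ug/mL to 45 ug/mL.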

Compound 4, solubility: 12.5 ug/mL
Compound 4: middle estimate off by 1.2-fold (0.08 log units), on the high side; measured number inside the range.
By their numbers in this assay, from the lowest: compounds 3, 4 and 2 (each within the scatter of the next, the first and the last beyond it). At a limit, above all of these: compound 1.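

In this assay the step is a 2.0-fold higher number from compound 3 to compound 4 (0.30 log units; within the scatter), so ethoxy and furan-2-yl are not told apart at this position, on an aromatic carbon meta to a large group and meta to a methyl group. A ring at this place is thus not required for a reading of this size: among the three groups on the shared core, only pyridin-2-yl stands apart, with an at least 8.0-fold lower number from compound 1 to compound 4 (0.90 log units; beyond the scatter) now set alongside an at least 15-fold lower number from compound 1 to compound 3 (1.20 log units; beyond the scatter). Compound 1 sits at a limit of the assay and not at a number, so both of these steps are known only as minimum sizes: the limit of > 100 ug/mL in this assay, at which 1 of the 4 values shown sits.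

From the compounds shown here alone, it remains open whether the gap to compound 1 follows pyridin-2-yl alone or would also appear with other rings holding a nitrogen, such as pyrimidin-2-yl or pyridin-3-yl. Going by these compounds, how an amine such as dimethylamino, a carboxylic acid or a longer chain such as butoxy would read in this assay at this same aromatic carbon is also open.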